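Swapping ethylamino for piperidin-1-yl without the chloro

A few compounds are considered here, and "the series" means these few. Any claim that something is new, unique, unknown or untested is made for them only; others in the source may bear on it.

In a functional assay on HeLa cells (Homo sapiens) for inhibition (on this read-out higher numbers stand for weaker inhibition and lower numbers for stronger inhibition), compound 1 `CCN(C(=O)CC(CC(=O)NCCN1CCCCC1)c1ccc(Cl)cc1)C1Cc2ccccc2C1` gives 20400 nM and compound 2 `CCNCCNC(=O)CC(CC(=O)N(CC)C1Cc2ccccc2C1)c1ccc(Cl)cc1` gives 40500 nM. Compound 3 `CCNCCNC(=O)CC(CC(=O)N(CC)C1Cc2ccccc2C1)c1ccccc1` gives > 100000 nM, which is a limit and not a number; it stands at the limit of > 100000 nM in this assay, at which 1 of the 3 values shown sits. Hydrogen in place of chloro gave an at least 2.4-fold higher number from compound 2 to compound 3 (0.39 log units; beyond the scatter). Compound 4 `CCN(C(=O)CC(CC(=O)NCCN1CCCCC1)c1ccccc1)C1Cc2ccccc2C1` differs from compound 3 by one change, (piperidin-1-yl in place of ethylamino on a saturated chain carbon, two bonds along the chain from an amide-type nitrogen), on a saturated chain carbon. The same exchange, read in the opposite direction, separates the chloro pair and gave only a 2.0-fold higher number from compound 1 to compound 2 (0.30 log units; within the scatter). A small step is therefore expected in this assay, towards a lower number if there is any change at all, estimated as an at least 1.2-fold lower number from compound 3 to compound 4 (0.09 log units; that floor lies within the scatter). For compound 4 the expected value is 80000 nM, with an estimated range of 40000 nM to 160000 nM.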

Compound 4, half-maximal inhibitory concentration: > 100000 nM
Compound 4: a limit, no number; the forecaster's own chance of this, stated with the estimate: 45%; middle value at least 1.2-fold (0.09 log units) from the limit.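

In this assay compound 4 gives > 100000 nM, which is a limit and not a number. Compound 3 also sits at a limit, so the step from ethylamino to piperidin-1-yl cannot be read without the chloro: the limit of > 100000 nM in this assay, at which 2 of the 4 values shown sit. Hydrogen in place of chloro now gives an at least 4.9-fold higher number from compound 1 to compound 4 (0.69 log units; beyond the scatter), so this change goes the same way with piperidin-1-yl as with ethylamino: the same change on two cores in this assay, an at least 2.4-fold higher number (0.39 log units; beyond the scatter) from compound 2 to compound 3 and an at least 4.9-fold higher number (0.69 log units; beyond the scatter) from compound 1 to compound 4; the limit leaves it open whether they differ.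

Going by these compounds, what bromo or fluoro in place of chloro would give on the aromatic carbon stays open. So does how dimethylamino on the saturated chain carbon would compare with piperidin-1-yl and ethylamino.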